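Chain-linked piperidine in place of the spiro azetidine

This account rests on a few compounds, and the source may have more. Where it says the series, first, only, none or still open, it means among the compounds named here.

Compound 3 `Cn1nc(-c2ccc(OCC3CC4(CNC4)C3)c(F)c2)c2cnc(N)nc21` gives 6500 nM in an assay on tissue (PBMC cells) for antagonist activity at Toll-like receptor 9 (Homo sapiens) (a lower number here means a stronger inhibitor, a higher number a weaker inhibitor), the highest number of the three measured. Compound 2 `Cn1nc(-c2ccc(OCC34CCC(O)(CC3)CC4)c(F)c2)c2cnc(N)nc21` gives 5300 nM, and a 1.2-fold higher number from compound 2 to compound 3 (0.09 log units; within the scatter), so these two cannot be told apart. Compound 1 `Cn1nc(-c2ccc(OC[C@H]3CC[C@H](N)CC3)c(F)c2)c2cnc(N)nc21` gives 1400 nM, and a 4.6-fold higher number from compound 1 to compound 3 (0.67 log units; beyond the scatter); likewise a 3.8-fold higher number from compound 1 to compound 2 (0.58 log units; beyond the scatter). Compound 4 `Cn1nc(-c2ccc(OCCCC3CCNCC3)c(F)c2)c2cnc(N)nc21` carries the change (a group of 8 heavy atoms (7 carbon, 1 nitrogen; one six-membered non-aromatic ring with 1 hetero atom) in place of a group of 7 heavy atoms (6 carbon, 1 nitrogen; one four-membered non-aromatic ring of carbon only, one four-membered non-aromatic ring with 1 hetero atom), on a saturated chain carbon bound to an oxygen on an aromatic ring). The step that bears on it is a 4.6-fold higher number from compound 1 to compound 3 (0.67 log units; beyond the scatter), in which a six-membered carbon ring bearing a nitrogen was exchanged for the spiro pair of four-membered rings and the number rose. For the measured compounds named here, compound 4 brings back a six-membered ring with one nitrogen, though on a longer link, so a partial reversal of that step is expected, a lower number, but the longer link has no measured counterpart and the range is wide. Compound 4 is therefore expected to give 2500 nM, between 900 nM and 7000 nM, which is an expected 2.6-fold lower number from compound 3 to compound 4 (0.41 log units; beyond the scatter).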

Compound 4, half-maximal inhibitory concentration: 2300 nM
Beside the measured number, compound 4's estimate is 1.1-fold (0.04 log units) above it; the measured number falls inside the stated range.
By their numbers in this assay, from the lowest: compounds 1 and 4 (each within the scatter of the next); then compounds 2 and 3 (each within the scatter of the next).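

In this assay, the 2-(piperidin-4-yl)ethyl group separates from two other groups at this place, with a 2.8-fold lower number from compound 3 to compound 4 (0.45 log units; beyond the scatter) and a 2.3-fold lower number from compound 2 to compound 4 (0.36 log units; beyond the scatter), while a 1.6-fold higher number from compound 1 to compound 4 (0.22 log units; within the scatter) leaves it not distinguishable from 4-aminocyclohexyl, so a second group now joins the lower range that only compound 1 occupied before. A nitrogen in the group is not sufficient to reach that range, as compound 3 also carries one and stands with compound 2. No measurement on hand speaks to what lies behind these differences.

The compounds shown do not separate the longer chain in compound 4 from the change of ring, which a piperidin-4-yl group on a shorter chain would address. From the compounds shown here alone, how a piperazine or morpholine ring on the same chain would read in this assay also stays open.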